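The source may report more compounds than this note shows. Statements on the series, on what has been measured and on what is new or still open speak of the compounds shown alone.

Measured so far:
compound 1, `Oc1cccc(-c2cc(-c3ccccc3F)cc(-c3ccccc3O)n2)c1` — 35600 nM
compound 2, `Oc1ccccc1-c1cc(-c2cccc(C(F)(F)F)c2)cc(-c2ccccc2O)n1` — > 50000 nM

In a functional assay on DU-145 cells (Homo sapiens) for inhibition (on this read-out higher numbers stand for weaker inhibition and lower numbers for stronger inhibition), compound 1 gives 35600 nM. For compound 2 the reported value > 50000 nM is a limit of this assay and not a number. This is the case of the limit of > 50000 nM in this assay, at which 1 of the 2 values shown sits. Compound 2 thus stands at the limit of the two values shown, while compound 1 has a measured number.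

Compound 3, `Oc1cccc(-c2cc(-c3cccc(C(F)(F)F)c3)cc(-c3ccccc3O)n2)c1`, is still to be measured in this assay. It differs from compound 2 in 3-hydroxyphenyl in place of 2-hydroxyphenyl on an aromatic carbon. Going by the values given here, no step between measured compounds is given for this change, so the expected size rests on the two values alone: compound 1 carries a 3-hydroxyphenyl group and gives a number, compound 2 does not and gives only a limit. The expected direction is toward a measurable number, with the step of an at least 1.2-fold lower number from compound 2 to compound 3 (0.09 log units; that floor lies within the scatter) from a limit judged to be no more than the scatter. Compound 3 is estimated at 40000 nM, within 15000 nM to 100000 nM, with a fair chance that again only a limit is reported.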

Compound 3, half-maximal inhibitory concentration: 13000 nM
The estimate for compound 3 lay 3.1-fold (0.49 log units) above the measured number, outside the stated range (below it).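

In this assay, 3-hydroxyphenyl in place of 2-hydroxyphenyl on the aromatic carbon next to the ring nitrogen, with the 3-(trifluoromethyl)phenyl group kept, gives an at least 3.8-fold lower number from compound 2 to compound 3 (0.58 log units; beyond the scatter), so this position is sensitive to where the hydroxyl stands on the ring even though the atoms are the same. The size of this step is only a bound, because the value for compound 2 is a limit and not a number: the limit of > 50000 nM in this assay, at which 1 of the 3 values shown sits. With the 3-hydroxyphenyl group kept, 3-(trifluoromethyl)phenyl in place of 2-fluorophenyl on an aromatic carbon gives a 2.7-fold lower number from compound 1 to compound 3 (0.44 log units; beyond the scatter), which shows that the series also responds to a change of this second aryl group and that compound 3 is the better of this matched pair.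

The compounds shown leave open whether the preference for 3-hydroxyphenyl holds with other partner groups, as the pair 2 and 3 tests it with a single one. They also leave open how the position would read with an amine or a carboxylic acid in place of the hydroxyl, or with the hydroxyl moved to give 4-hydroxyphenyl.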